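Chlorine position on the benzylthio arm: 3-chloro to 4-chloro

A few compounds are considered here, and "the series" means these few. Any claim that something is new, unique, unknown or untested is made for them only; others in the source may bear on it.

Compound 3 `CC1=C(C(=O)Nc2ccc(F)cc2)C(c2ccc([N+](=O)[O-])cc2)N=C(SCc2cccc(Cl)c2)N1` is one of three analogues measured in a functional assay on the whole organism (artery, strain albino) with Rattus norvegicus as the target, with a stated time of 180 min, at a dose of 10 mg/kg by the oral route (on this read-out lower numbers stand for less inhibition and higher numbers for more inhibition at the one dose given (going by the name of the read-out)), where compound 3 gives 11.9%. Compound 2 `CC1=C(C(=O)Nc2ccc(F)cc2)C(c2ccc([N+](=O)[O-])cc2)N=C(SCc2ccccc2Cl)N1` gives 12.4% in this assay, and compound 1 `COc1ccc(C2N=C(SCc3ccc(Cl)cc3)NC(C)=C2C(=O)Nc2ccc(F)cc2)cc1OC` gives 20.1%. On these numbers compound 3 sits alongside both: the step from compound 2 to compound 3 is a number 0.5 percentage points lower from compound 2 to compound 3 (within the scatter), and the gap to compound 1 is likewise inside the scatter, so no ordering among the three can be read from this assay.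

Compound 4 `CC1=C(C(=O)Nc2ccc(F)cc2)C(c2ccc([N+](=O)[O-])cc2)N=C(SCc2ccc(Cl)cc2)N1` differs from compound 3 only by 4-chlorophenyl in place of 3-chlorophenyl on a saturated chain carbon bound to a sulfur. For the measured compounds named here, the one measured step at this same place, moving the chlorine from the 2- to the 3-position, was within the scatter. Going by the values given here, compound 1 also carries a 4-chlorophenyl on the saturated chain carbon bound to a sulfur, but its core differs elsewhere from compound 3, so its value shows only that such a compound can give a number near those of compound 2 and compound 3. On this basis the expected step from compound 3 to compound 4 in this assay is a number 2.1 percentage points higher from compound 3 to compound 4 (within the scatter), none beyond the scatter. Compound 4 is therefore estimated at 14%, with a range from 4% to 26%.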

Compound 4, a percentage reported as inhibition, in the whole organism at one dose (the size of the read-out at that dose, not a potency): 23.2%
Compound 4: middle estimate off by 9.2 percentage points, on the low side; low and high end bracket the measured number.
By their numbers in this assay, from the lowest: compounds 3, 2, 1 and 4 (each within the scatter of the next, the first and the last beyond it).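

In this assay the position of the chlorine on the benzylthio arm now shows an effect on the shared core: 4-chlorophenyl in place of 3-chlorophenyl on a saturated chain carbon bound to a sulfur gives a number 11.3 percentage points higher from compound 3 to compound 4 (beyond the scatter) and replaces a flat picture, while the same group in place of 2-chlorophenyl gives a number 10.8 percentage points higher from compound 2 to compound 4 (beyond the scatter) as a second step of like size. Among these three, only the 4-chlorobenzyl compound stands apart, since compound 2 and compound 3 remain within the scatter of each other. With 4-chlorophenyl held fixed, the change on the saturated ring carbon gives a number 3.1 percentage points higher from compound 1 to compound 4 (within the scatter) and so separates nothing here.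

As far as these compounds go, whether a methyl, a methoxy or a bromine in place of the chlorine on 4-chlorophenyl would hold this step remains open. No measurement at hand offers an explanation of why 4-chlorophenyl stands apart from the other two placements.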